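A few compounds are considered here, and "the series" means these few. Any claim that something is new, unique, unknown or untested is made for them only; others in the source may bear on it.

Measured so far in an assay on CHO cells for displacement of a labelled ligand from adenosine receptor A1 (Homo sapiens), read by scintillation counting, with a stated time of 90 min; on this read-out lower numbers stand for stronger inhibition and higher numbers for weaker inhibition:
Compound 1 `N#Cc1c(N)nc(SCc2cccnc2)c(C#N)c1-c1ccc(OCC2CC2)cc1` gives 67 nM.
Compound 2 `CC(C)COc1ccc(-c2c(C#N)c(N)nc(SCC(N)=O)c2C#N)cc1` gives 603 nM.
Compound 3 `CCOc1ccc(-c2c(C#N)c(N)nc(SCC(N)=O)c2C#N)cc1` gives 345 nM.

Compound 1 stands lowest of the three in this assay; its gaps to compound 3 and to compound 2 both lie beyond the scatter. Within the data shown here, the only measured step, a 1.7-fold lower number from compound 2 to compound 3 (0.24 log units; within the scatter), concerns the alkoxy side of the shared core and is within the scatter, so it says nothing about the sulfur-bound chain.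

Compound 4 `N#Cc1c(N)nc(SCC(=O)NO)c(C#N)c1-c1ccc(OCC2CC2)cc1` is the next compound: hydroxycarbamoyl in place of pyridin-3-yl on a saturated chain carbon bound to a sulfur. Among the measured compounds shown here, no measured pair isolates this change. The closest reference is that compounds 2 and 3, which carry a carbamoylmethyl group on the sulfur rather than the (pyridin-3-yl)methyl of compound 1, both show clearly higher numbers than compound 1, though they also differ from compound 1 in the alkoxy group. Hydroxycarbamoyl resembles carbamoyl, so compound 4 is expected to move toward the range of compounds 2 and 3, a weakening step a 5.2-fold higher number from compound 1 to compound 4 (0.72 log units; beyond the scatter). The estimate for compound 4 in this assay is 350 nM, with a range from 100 nM to 1200 nM.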

Compound 4, inhibition constant: 536 nM
Compound 4: the middle estimate sits 1.5-fold (0.19 log units) below what was measured; the range from low to high includes it.
By their numbers in this assay, from the lowest: compound 1; then compounds 3, 4 and 2 (each within the scatter of the next).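

Within this assay there is now an 8.0-fold higher number from compound 1 to compound 4 (0.90 log units; beyond the scatter) for a change confined to the sulfur-bound chain, with the alkoxy side of the shared core held constant. Among these compounds, this is the first pair to isolate this position, and it shows that the number responds beyond the scatter when hydroxycarbamoyl takes the place of pyridin-3-yl on a saturated chain carbon bound to a sulfur. No measurement at hand offers an explanation for this step.

Among the compounds shown here, the single pair cannot separate the loss of the pyridin-3-yl ring from the entry of hydroxycarbamoyl, so either could account for the higher number. A phenyl ring, a carboxylic acid or a longer chain at the same place, on the core of compound 1, would help to tell these two readings apart.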